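Trimming a methoxy from the aryl ketone of compound 3

This account rests on a few compounds, and the source may have more. Where it says the series, first, only, none or still open, it means among the compounds named here.

Three compounds share one core and differ only in the aryl group attached to the carbonyl carbon. Compound 1 `COc1cc(-c2cc(/C=C/C(=O)c3ccc(N)cc3)[nH]n2)cc(OC)c1OC` carries a 4-aminophenyl there; in a functional assay on SK-MEL-5 cells (Homo sapiens) for inhibition, read by sulforhodamine B assay, with a stated time of 48 h (on this read-out higher numbers stand for weaker inhibition of growth and lower numbers for stronger inhibition of growth), compound 1 gives 1650 nM. Compound 2 `COc1cc(-c2cc(/C=C/C(=O)c3ccc(Cl)c(Cl)c3)[nH]n2)cc(OC)c1OC` carries a 3,4-dichlorophenyl, and in this assay compound 2 gives 13400 nM, which is an 8.1-fold higher number from compound 1 to compound 2 (0.91 log units; beyond the scatter). Compound 3 `COc1ccc(C(=O)/C=C/c2cc(-c3cc(OC)c(OC)c(OC)c3)n[nH]2)cc1OC` carries a 3,4-dimethoxyphenyl, and in this assay compound 3 gives 1650 nM. That reads as no change at the digits printed from compound 1 to compound 3 (within the scatter) and as an 8.1-fold lower number from compound 2 to compound 3 (0.91 log units; beyond the scatter), so compound 3 stands level with compound 1 and the two together hold the lowest numbers of the three.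

Compound 4 `COc1ccc(C(=O)/C=C/c2cc(-c3cc(OC)c(OC)c(OC)c3)n[nH]2)cc1` is the next step: hydrogen in place of methoxy on an aromatic carbon. For the measured compounds named here, no measured step removes a single methoxy, so the evidence is indirect. The swap from 4-aminophenyl to 3,4-dimethoxyphenyl left the number unchanged, while only the dichloro aryl moved it, and then modestly. Losing one methoxy is a smaller change than either swap, so no shift beyond the scatter is expected, with a slight lean toward a higher number: the expected step is a 1.5-fold higher number from compound 3 to compound 4 (0.18 log units; within the scatter). For compound 4 in this assay the estimate is 2500 nM, between 900 nM and 7000 nM.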

Compound 4, concentration for 50% growth inhibition: 1720 nM
For compound 4 the middle estimate is 1.5-fold (0.16 log units) above the measured one; low and high end bracket the measured number.
By their numbers in this assay, from the lowest: compounds 1, 3 and 4 (each within the scatter of the next); then compound 2.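

Cutting 3,4-dimethoxyphenyl back to 4-methoxyphenyl in this assay gives the first direct reading of this methoxy group, the one ortho to a methoxy group (a 1.0-fold higher number from compound 3 to compound 4 (0.02 log units; within the scatter)), and the number stays within the scatter, so this read-out does not depend on that group. Compound 4 also sits within the scatter of the aminophenyl compound (a 1.0-fold higher number from compound 1 to compound 4 (0.02 log units; within the scatter)) and keeps the same clear gap from the dichloro compound as compound 3 does (a 7.8-fold lower number from compound 2 to compound 4 (0.89 log units; beyond the scatter)), which leaves the 3,4-dichlorophenyl as the only aryl group among these four that stands apart. Nothing measured here explains why the number holds steady across these aryl groups or why the dichloro compound differs.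

The compounds shown leave open whether the remaining methoxy matters, which a plain phenyl ketone with only hydrogen in its place would begin to test. They also leave open how far that spot can be pushed, for example with a longer chain such as butoxy or with a carboxylic acid.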